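The compounds below may be only part of what the source reports. "The series", "measured", "known", "first", "only" and "open" are said of these compounds alone.

Working notes on the series around compound 3 (`COc1c(Br)cccc1C(=O)Nc1ccc(Sc2nc3ccccc3s2)cc1`). In an ADME assay on HEK293 cells (Homo sapiens) for cytotoxicity, read by reporter gene assay and resazurin assay, with a stated time of 48 h (on this read-out higher numbers stand for lower toxicity in this test and lower numbers for higher toxicity in this test), compound 3 gives > 100000 nM, which is a limit of the assay and not a number. Compound 2 (`COc1ccccc1C(=O)Nc1ccc(Sc2nc3ccccc3s2)cc1`) gives > 100000 nM, also a limit. Going by the values given here, compound 1 (`O=C(Nc1ccc(Sc2nc3ccccc3s2)c(Cl)c1)c1cccc(Br)c1O`) gives 64000 nM, the only true number so far. Compound 3 thus stands at the limit of > 100000 nM in this assay, at which 2 of the 3 values shown sit.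

The next change leads to compound 4 (`O=C(Nc1ccc(Sc2nc3ccccc3s2)cc1)c1cccc(Br)c1O`): hydrogen in place of methyl on an oxygen on an aromatic ring, that is, methoxy to hydroxy. Among the compounds with values here, the one measured step is a step that the two limits leave unreadable from compound 2 to compound 3. It concerns bromo in place of hydrogen on an aromatic carbon, not this change, so no size carries over from it.

Within the data shown here, the only other guide is indirect. Compound 4 shares the hydroxy with compound 1, which also carries a chloro and gives 64000 nM. A move towards lower numbers in this assay is therefore expected, though compound 4 may well stay at the limit. The expected change is an at least 1.4-fold lower number from compound 3 to compound 4 (0.15 log units; that floor lies within the scatter). For compound 4 the estimated value is 70000 nM, with an expected range of 30000 nM to 100000 nM.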

Compound 4, half-maximal cytotoxic concentration: 71000 nM
Compound 4: middle estimate off by 1.0-fold (0.01 log units), on the low side, within the range that was stated.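

In this assay, going by these compounds alone, compound 4 gives a true number where compound 3 gives only a limit, so this change on an oxygen on an aromatic ring is the first one that can be read at all, if only as a floor: an at least 1.4-fold lower number from compound 3 to compound 4 (0.14 log units; that floor lies within the scatter). The wider change, 3-bromo-2-hydroxyphenyl in place of 2-methoxyphenyl on a carbonyl carbon, also gives only a floor, an at least 1.4-fold lower number from compound 2 to compound 4 (0.14 log units; that floor lies within the scatter), and the full size of both steps stays unknown because their starting compounds sit at a limit: the limit of > 100000 nM in this assay, at which 2 of the 4 values shown sit.

The chloro of compound 1 is not needed for a true number in this test, since hydrogen in place of chloro on an aromatic carbon gives a 1.1-fold higher number from compound 1 to compound 4 (0.05 log units; within the scatter).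

On these data alone, the step between the two methoxy compounds cannot be read, so what bromo does on its own stays open, on the methoxy compounds and on the hydroxy compound alike. Also open, as far as these compounds go, is whether an amine or a carboxylic acid in place of the hydroxy would keep the number in this range or return it to the limit.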